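Carboxylic Acid in Place of Nitrile: Solubility Outlook

This account rests on a few compounds, and the source may have more. Where it says the series, first, only, none or still open, it means among the compounds named here.

compound 1, `COc1ccnc(Nc2cc3[nH]c(-c4cccc(C(F)(F)F)c4)nc3cn2)c1`: < 5000 nM
compound 2, `N#Cc1ccc(Nc2cc3[nH]c(-c4cccc(C(F)(F)F)c4)nc3cn2)nc1`: < 5000 nM

In a physicochemical assay for solubility, using the shake flask method, measured as kinetic solubility, with a stated time of 20 h, at pH 2 (a higher number here means a more soluble compound, a lower number a less soluble compound), compound 1 gives only a limit of the assay, < 5000 nM. Compound 2 likewise gives only a limit in this assay, < 5000 nM. Among the measured compounds shown here, the one measured step, a step that the two limits leave unreadable from compound 1 to compound 2, is therefore unreadable, since (the limit of < 5000 nM in this assay, at which 2 of the 2 values shown sit).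

Compound 3, `O=C(O)c1ccnc(Nc2cc3[nH]c(-c4cccc(C(F)(F)F)c4)nc3cn2)c1`, differs from compound 2 by 4-carboxypyridin-2-yl in place of 5-cyanopyridin-2-yl on a nitrogen on an aromatic ring. For the measured compounds named here, no measured step involves a carboxyl group, and the single step recorded cannot be sized, so the data give no direction for this change. On that basis the step that the limit leaves unreadable from compound 2 to compound 3 is expected to be none that can be read beyond the scatter, with compound 3 most likely again sitting at the limit. Compound 3 is estimated at 4000 nM in this assay, within a range from 800 nM to 20000 nM.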

Compound 3, solubility: < 5000 nM
Compound 3 was reported as a limit; the forecaster's own chance of this, stated with the estimate: 60%; the middle value lies beyond the limit too.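

Compound 3 gives the limit < 5000 nM in this assay as well. Among the compounds shown here, no step among compound 1, compound 2 and compound 3 can be read, all three sitting at one limit: the limit of < 5000 nM in this assay, at which 3 of the 3 values shown sit. The compounds shown leave open how these three actually rank against one another.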